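Methoxy substitution of compound 3

A few compounds are considered here, and "the series" means these few. Any claim that something is new, unique, unknown or untested is made for them only; others in the source may bear on it.

Among the measured compounds shown here, compound 3 `O=C(CCCCC1CCSS1)NCc1cn(CCCOc2ccc3cc(-c4ccccc4)c(=O)oc3c2)nn1` gives 29.1% in a functional assay on PC-12 cells (Rattus norvegicus) for cytotoxicity, read by MTT assay, with stated times of 3 h and 2 h, tested at 10 uM (a higher number here means a stronger effect of the compound at the concentration tested, a lower number a weaker effect), the lowest of the three numbers so far. Compound 1 `CCOC(=O)c1cc2ccc(OCCCn3cc(CNC(=O)CCCCC4CCSS4)nn3)cc2oc1=O` gives 36.1%, and the two values lie within the scatter of each other; compound 2 `O=C(CCCCC1CCSS1)NCc1cn(CCCOc2ccc3cc(C(=O)O)c(=O)oc3c2)nn1` gives 59.9%, with a number 30.8 percentage points lower from compound 2 to compound 3 (beyond the scatter). The other measured steps are a number 23.8 percentage points higher from compound 1 to compound 2 (beyond the scatter) and a number 7 percentage points lower from compound 1 to compound 3 (within the scatter). Compound 4 `COc1ccc(-c2cc3ccc(OCCCn4cc(CNC(=O)CCCCC5CCSS5)nn4)cc3oc2=O)cc1` differs from compound 3 by methoxy in place of hydrogen on an aromatic carbon, which, cut one bond further out, reads phenyl to 4-methoxyphenyl. For the measured compounds named here, none of the measured steps alters this phenyl itself; the steps that touch this part of the shared core exchange the whole group, and the one nearest in kind, a number 7 percentage points lower from compound 1 to compound 3 (within the scatter), stays within the scatter. Nothing in the series therefore points to a step beyond the scatter in this assay, and for compound 4 the expected change is a number 0.9 percentage points higher from compound 3 to compound 4 (within the scatter). Compound 4 is estimated at 30%, with a range of 15% to 45%.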

Compound 4, a percentage reported as activity, at one concentration (the size of the read-out at that concentration, not a potency): 57.6%
Compound 4: middle estimate off by 27.6 percentage points, on the low side; measured number above the stated range.
By their numbers in this assay, from the lowest: compounds 3 and 1 (each within the scatter of the next); then compounds 4 and 2 (each within the scatter of the next).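

In this assay, among the compounds shown here, the only step that alters the phenyl itself moves the read-out beyond the scatter (a number 28.5 percentage points higher from compound 3 to compound 4 (beyond the scatter)), so this position responds to a small substituent and not only to exchange of the whole group. With methoxy para to the large group, the phenyl series no longer sits low: the carboxy compound is matched within the scatter (a number 2.3 percentage points lower from compound 2 to compound 4 (within the scatter)), and the ethoxycarbonyl compound is now exceeded beyond it (a number 21.5 percentage points higher from compound 1 to compound 4 (beyond the scatter)). No measurement at hand explains the rise.

Open, from the compounds shown here alone, is whether a hydroxy group, a chlorine atom or an amine in the same place on the phenyl gives a similar number. Also open, going by these compounds, is whether a longer alkoxy chain there keeps the number of compound 4.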